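Aryl Swap on the Chlorophenyl Arm: Outlook for Compound 3

The compounds below may be only part of what the source reports. "The series", "measured", "known", "first", "only" and "open" are said of these compounds alone.

Measured so far:
compound 1, `Cn1nc2c(=O)n(CC3(O)CCN(Cc4ccc(-c5ccncc5)cc4Cl)CC3)cnc2c1-c1ccc(CN)cc1`: 257 nM
compound 2, `Cn1nc2c(=O)n(CC3(O)CCN(Cc4ccc(-c5ccco5)cc4Cl)CC3)cnc2c1-c1ccc(CNC=O)cc1`: 20.9 nM

In an assay on isolated protein for inhibition of ubiquitin carboxyl-terminal hydrolase 7 (Homo sapiens), with stated times of 30 min and 2 h (on this read-out higher numbers stand for weaker inhibition and lower numbers for stronger inhibition), compound 1 gives 257 nM and stands highest of the two numbers; compound 2 gives 20.9 nM, a lower number beyond the scatter, but compound 2 differs from compound 1 in two places, so the two values show only that gap. Compound 3, `Cn1nc2c(=O)n(CC3(O)CCN(Cc4ccc(-n5ccnc5)cc4Cl)CC3)cnc2c1-c1ccc(CN)cc1`, carries 1H-imidazol-1-yl in place of pyridin-4-yl on an aromatic carbon. Among the measured compounds shown here, no measured pair isolates this change, so the step in this assay is expected to be small and in no set direction, likely within the scatter. The expected step is a 1.0-fold lower number from compound 1 to compound 3 (0.01 log units; within the scatter). Compound 3 is estimated at 250 nM, with a range from 80 nM to 800 nM.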

Compound 3, half-maximal inhibitory concentration: 228 nM
For compound 3 the middle estimate is 1.1-fold (0.04 log units) above the measured one, within the range that was stated.
By their numbers in this assay, from the lowest: compound 2; then compounds 3 and 1 (each within the scatter of the next).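

Among the compounds shown here, at this position, on an aromatic carbon para to a large group and meta to a chloro group, compound 3 gives the first single-change comparison in this assay (a 1.1-fold lower number from compound 1 to compound 3 (0.05 log units; within the scatter)). The six-membered pyridin-4-yl ring and the five-membered 1H-imidazol-1-yl ring are therefore not separated by this read-out. No evidence bears on why this swap leaves the values within the scatter.

Compound 2 (20.9 nM) differs from compound 1 and compound 3 in two places, so its furan ring and formamide cannot be separated. On these data alone, a phenyl or morpholin-4-yl group at this position remains open.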